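The compounds below may be only part of what the source reports. "The series", "measured", "known", "first", "only" and "open" are said of these compounds alone.

The series shares one core, seen in compound 1 `CC1(C)[C@H]2CC[C@]1(C)N(Cc1cn(-c3cccc(F)c3)nn1)C(=O)C2` and compound 2 `CC1(C)[C@H]2CC[C@]1(C)N(Cc1cn(-c3ccc(C#N)cc3)nn1)C(=O)C2`, and differs only in the aryl group carried on an aromatic nitrogen. In a functional assay on A549 cells (Homo sapiens) for inhibition, read by MTT assay, with a stated time of 24 h (a lower number here means a stronger inhibitor, a higher number a weaker inhibitor), compound 1 gives 180 nM, and in the same assay compound 2 gives 140 nM. Compound 2 stands alongside compound 1 as one of just two numbers measured, separated from it by a 1.3-fold lower number from compound 1 to compound 2 (0.11 log units; within the scatter), a step that stays within the scatter, so neither compound can be called the stronger inhibitor.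

Compound 3 `CC1(C)[C@H]2CC[C@]1(C)N(Cc1cn(-c3ccccc3F)nn1)C(=O)C2` is the next member: 2-fluorophenyl in place of 4-cyanophenyl on an aromatic nitrogen. Within the data shown here, the only measured step that bears on this change is the aryl swap from compound 1 to compound 2, a 1.3-fold lower number from compound 1 to compound 2 (0.11 log units; within the scatter), which did not move the number beyond the scatter. On that basis a further aryl swap is expected to leave this assay number roughly where compound 2 sits, with no step beyond the scatter in either direction, so a 1.4-fold higher number from compound 2 to compound 3 (0.13 log units; within the scatter) is the expected shift. Compound 3 is therefore estimated at 190 nM, with a likely range from 80 nM to 450 nM.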

Compound 3, half-maximal inhibitory concentration: 240 nM
Beside the measured number, compound 3's estimate is 1.3-fold (0.10 log units) below it, within the range that was stated.
By their numbers in this assay, from the lowest: compounds 2, 1 and 3 (each within the scatter of the next).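

In this assay, 2-fluorophenyl in place of 4-cyanophenyl on the aromatic nitrogen gives a 1.7-fold higher number from compound 2 to compound 3 (0.23 log units; within the scatter), and 2-fluorophenyl in place of 3-fluorophenyl gives a 1.3-fold higher number from compound 1 to compound 3 (0.12 log units; within the scatter). The earlier pair offered only one aryl swap; these steps add a comparison of two fluorophenyl isomers and show that all three aryl groups shown, compared pair by pair, stay within the scatter, so compounds 1, 2 and 3 cannot be put in order of strength. Nothing is available that would explain this flat result or link any of these numbers to a feature of the groups.

The compounds shown leave open whether the number at this position would stay within the scatter with a phenyl ring carrying an amine or a carboxylic acid, or with a longer alkyl chain in place of the aryl ring. They also leave open whether the same holds for a change anywhere other than this aromatic nitrogen, since the shared core and its link to the five-membered ring are the same in compounds 1, 2 and 3.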